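Adding a side chain to compound 2

This account rests on a few compounds, and the source may have more. Where it says the series, first, only, none or still open, it means among the compounds named here.

Compound 1 `Cc1ccc2oc(-c3c4c(N)n[nH]c(=O)c4nn3-c3ccc(NC(=O)/C=C/CN(C)C)cc3)c(C)c2c1`: < 0.3 nM (a limit)
Compound 2 `Cc1ccc2oc(-c3c4c(N)n[nH]c(=O)c4nn3-c3ccccc3)c(C)c2c1`: 416 nM

Among the measured compounds shown here, in a functional assay on KG-1 cells (Homo sapiens) for antiproliferative activity, read by CCK-8 assay, with a stated time of 72 h (on this read-out higher numbers stand for weaker inhibition and lower numbers for stronger inhibition), compound 2 gives 416 nM, the only actual number so far. Compound 1 has only a limit, < 0.3 nM.

Compound 3 `C=CC(=O)NCc1ccc(-n2nc3c(=O)[nH]nc(N)c3c2-c2oc3ccc(C)cc3c2C)cc1` carries ((vinylcarbonyl)amino)methyl in place of hydrogen on an aromatic carbon of compound 2, para to a large group (((vinylcarbonyl)amino)methyl in place of hydrogen on an aromatic carbon).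

For the measured compounds named here, the one measured step bearing on this is an at least 1300-fold higher number from compound 1 to compound 2 (3.14 log units; beyond the scatter), where hydrogen takes the place of ((3-(dimethylamino)prop-1-en-1-yl)carbonyl)amino on an aromatic carbon. That step is large and runs opposite to the change considered here, which adds a chain instead of removing one. The two chains are not the same, so only part of that step is expected to carry over. The expected change is a 42-fold lower number from compound 2 to compound 3 (1.62 log units; beyond the scatter), a large move towards stronger inhibition, though smaller than the measured step. In this assay the estimate for compound 3 is 10 nM, with an expected range from 0.8 nM to 120 nM.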

Compound 3, half-maximal inhibitory concentration: 0.6 nM
Compound 3: middle estimate off by 17-fold (1.22 log units), on the high side; the measured number lies below the stated range.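

In this assay, this carbon of the six-membered aromatic ring, para to a large group, now shows a large response to a second, different chain: ((vinylcarbonyl)amino)methyl gives a 690-fold lower number from compound 2 to compound 3 (2.84 log units; beyond the scatter). The large step seen earlier is therefore not confined to the ((3-(dimethylamino)prop-1-en-1-yl)carbonyl)amino chain, since both compounds carrying a chain here sit far from the unsubstituted compound 2, and neither goes against this within the three compounds shown. Exchanging one chain for the other gives an at least 2.0-fold higher number from compound 1 to compound 3 (0.30 log units; that floor lies within the scatter), so no difference between the two chains can be claimed, and the figure for compound 1 is a limit rather than a number, which leaves the true gap unreadable because the comparison rests on: the limit of < 0.3 nM in this assay, at which 1 of the 3 values shown sits.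

The compounds shown leave open whether the vinyl group itself is needed, which an ((ethylcarbonyl)amino)methyl group with its saturated chain would test, or whether a plain aminomethyl group at the same carbon would already suffice. They also leave open how a longer chain between the ring and the amide would fare.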